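This account rests on a few compounds, and the source may have more. Where it says the series, first, only, none or still open, it means among the compounds named here.

Measured so far:
Compound 1, `Cc1c(/N=C/c2ccccc2Cl)c(=O)n(-c2ccccc2)n1C`, in a functional assay on HT-29 cells (Homo sapiens) for cytotoxicity, read by MTT assay, with a stated time of 72 h (on this read-out lower numbers stand for stronger inhibition and higher numbers for weaker inhibition), compound 1 gives 309000000 nM.
Compound 2, `Cc1c(/N=C/c2ccc(Cl)cc2)c(=O)n(-c2ccccc2)n1C`, in this assay compound 2 gives 309000000 nM.

For the measured compounds named here, compound 2 stands level with compound 1: the one step measured, no change at the digits printed from compound 1 to compound 2 (within the scatter), shows that moving the chloro substituent on the aromatic ring left the read-out unchanged within the scatter. Both compounds sit at the same, very weak, end of the scale.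

Compound 3, `Cc1c(/N=C/c2ccc(O)cc2)c(=O)n(-c2ccccc2)n1C`, has not been measured. Going by the values given here, its only difference from compound 2 is hydroxy in place of chloro on an aromatic carbon. Among the compounds with values here, no measured step tests this particular swap of chloro for hydroxy, so the only guide is that the one change tried so far on this ring, no change at the digits printed from compound 1 to compound 2 (within the scatter), produced nothing beyond the scatter. On that basis a step of about no change at the digits printed from compound 2 to compound 3 (within the scatter) is expected, in no particular direction. Compound 3 is therefore estimated at 309000000 nM, with a likely range from 150000000 nM to 650000000 nM.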

Compound 3, half-maximal inhibitory concentration: 389000000 nM
Compound 3: middle estimate off by 1.3-fold (0.10 log units), on the low side, within the range that was stated.
By their numbers in this assay, from the lowest: compounds 1, 2 and 3 (each within the scatter of the next).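

In this assay, hydroxy in place of chloro puts a hydrogen-bond donor and acceptor on this aromatic carbon, yet the result is a 1.3-fold higher number from compound 2 to compound 3 (0.10 log units; within the scatter). So a different kind of group here, and not only a chloro moved around the ring, leaves the number within the scatter, and the wider comparison, a 1.3-fold higher number from compound 1 to compound 3 (0.10 log units; within the scatter), also stays within it, with all three compounds together at the very weak end of the scale. Nothing available explains why these changes make so little difference.

Still open, going by these compounds, is whether another group at this place, such as an amine, a carboxylic acid or a longer chain like butoxy, would move the number beyond the scatter. Also open, on these data alone, is whether changes elsewhere on the shared core would matter more than changes on this ring.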